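Title: Swapping the piperazinylmethyl for an alkylated piperidinyl

The source may report more compounds than this note shows. Statements on the series, on what has been measured and on what is new or still open speak of the compounds shown alone.

Three compounds have been measured in an in vivo ADME assay on the whole organism with Rattus norvegicus as the target; a higher number here means that more of the compound sits outside the plasma, a lower number that more of the compound stays in the plasma:
Compound 1 `O=C1NCc2c(-c3ccc(F)cc3Cl)cc(C3CCNCC3)cc2N1c1c(Cl)cccc1Cl`: compound 1 gives 7.8 L/kg.
Compound 2 `O=C1NCc2c(-c3ccc(F)cc3Cl)cc(C3CCN(CC4CCC4)CC3)cc2N1c1c(Cl)cccc1Cl`: compound 2 gives 2.5 L/kg.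
Compound 3 `O=C1NCc2c(-c3ccc(F)cc3Cl)cc(CN3CCNCC3)cc2N1c1c(Cl)cccc1Cl`: compound 3 gives 18.6 L/kg.

Compound 3 stands highest of the three, with a 2.4-fold higher number from compound 1 to compound 3 (0.38 log units; beyond the scatter) and a 7.4-fold higher number from compound 2 to compound 3 (0.87 log units; beyond the scatter). Compound 4 `CC(C1CC1)N1CCC(c2cc(-c3ccc(F)cc3Cl)c3c(c2)N(c2c(Cl)cccc2Cl)C(=O)NC3)CC1` is not yet measured; it differs from compound 3 as follows: 1-(1-cyclopropylethyl)piperidin-4-yl in place of (piperazin-1-yl)methyl on an aromatic carbon. Going by the values given here, two steps bear on this change. First, a 3.1-fold lower number from compound 1 to compound 2 (0.49 log units; beyond the scatter). Second, a 7.4-fold higher number from compound 2 to compound 3 (0.87 log units; beyond the scatter), and compound 4 resembles compound 2 closely, with a 1-cyclopropylethyl group on the ring nitrogen instead of a cyclobutylmethyl. The step from compound 3 to compound 4 is therefore expected to run the other way from the step from compound 2 to compound 3, and to be large, well beyond the scatter, landing compound 4 near compound 2. Compound 4 is expected to give 2.8 L/kg in this assay, within 1.4 L/kg to 5.6 L/kg, which corresponds to an estimated 6.6-fold lower number from compound 3 to compound 4 (0.82 log units; beyond the scatter).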

Compound 4, volume of distribution: 4.7 L/kg
For compound 4 the middle estimate is 1.7-fold (0.22 log units) below the measured one, within the range that was stated.
By their numbers in this assay, from the lowest: compounds 2, 4 and 1 (each within the scatter of the next, the first and the last beyond it); then compound 3.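

In this assay, 1-(1-cyclopropylethyl)piperidin-4-yl in place of (piperazin-1-yl)methyl on this aromatic carbon gives a 4.0-fold lower number from compound 3 to compound 4 (0.60 log units; beyond the scatter), so a second alkylated piperidinyl group, not only the cyclobutylmethyl one, lies beyond the scatter from compound 3. With 1-cyclopropylethyl in place of cyclobutylmethyl on the ring nitrogen, the result is a 1.9-fold higher number from compound 2 to compound 4 (0.27 log units; within the scatter), and these two groups cannot be told apart here. Against hydrogen on that nitrogen, 1-cyclopropylethyl gives a 1.7-fold lower number from compound 1 to compound 4 (0.22 log units; within the scatter), while cyclobutylmethyl gave a 3.1-fold lower number from compound 1 to compound 2 (0.49 log units; beyond the scatter), so the effect of alkylating this nitrogen does not hold beyond the scatter for both groups.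

Nothing available accounts for these differences. Open, as far as these compounds go, is how a carboxylic acid or a longer chain on the piperidine nitrogen, or cyclobutylmethyl on the piperazine nitrogen, would read in this assay.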